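The compounds below may be only part of what the source reports. "The series", "measured", "known", "first", "only" and "open" are said of these compounds alone.

Working notes on the aryl thioether series.

The reference compound is compound 1 `COc1ccc(SCc2ccc(/C=C/C(=O)Nc3ccccc3N)cc2)cc1OC`. Within the data shown here, in a functional assay on A-375 cells (Homo sapiens) for inhibition, read by CCK-8 assay, with a stated time of 72 h, tested at 2 uM (a lower number here means less inhibition of growth, a higher number more inhibition of growth at the concentration tested), compound 1 gives 46%, the highest of the three numbers so far. The nearest is compound 3 `Nc1ccccc1NC(=O)c1ccc(CSc2cccc(F)c2)cc1`, which in this assay gives 37.7%; that gap to compound 1 lies within the scatter. The furthest is compound 2 `Cc1ccc(SCc2ccc(C(=O)Nc3ccccc3N)cc2)cc1`, which in this assay gives 17.5%; that gap lies beyond the scatter.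

Among the measured compounds shown here, the only step measured so far within a single place is a number 20.2 percentage points higher from compound 2 to compound 3 (beyond the scatter). It sits on the same sulfur but on a core that lacks the double bond of compound 1, so it speaks only indirectly for the change at hand. It shows that swapping the aryl group on the sulfur can move this assay by a modest, real amount.

The unmeasured compound is compound 4 `CC(C)(C)c1ccc(SCc2ccc(/C=C/C(=O)Nc3ccccc3N)cc2)cc1`. The change from compound 1 is 4-(tert-butyl)phenyl in place of 3,4-dimethoxyphenyl on a sulfur. For the measured compounds named here, no measured step pairs a 3,4-dimethoxyphenyl with a 4-(tert-butyl)phenyl, so the direction is open. Given that the one aryl swap on the sulfur produced a modest step, a change of similar size in either direction, or none beyond the scatter, is expected; the estimate leans slightly downward, as a number 8 percentage points lower from compound 1 to compound 4 (within the scatter). For compound 4 the estimated value in this assay is 38%, with a range from 18% to 58%.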

Compound 4, percent growth inhibition at one concentration: 38.4%
Compound 4: the middle estimate sits 0.4 percentage points below what was measured; measured number inside the range.
By their numbers in this assay, from the lowest: compound 2; then compounds 3, 4 and 1 (each within the scatter of the next).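

Among these compounds, on the core of compound 1, which keeps the double bond, the aryl swap on the sulfur in this assay gives a number 7.6 percentage points lower from compound 1 to compound 4 (within the scatter), the first reading of such a change on this core. Among the compounds shown here, the replacement of 3,4-dimethoxyphenyl by 4-(tert-butyl)phenyl keeps the heavy-atom count and the single aromatic ring but takes the hydrogen-bond acceptor count of that group to 0, and the read-out at this one concentration does not separate the two compounds; the earlier aryl swap on the core without the double bond, a number 20.2 percentage points higher from compound 2 to compound 3 (beyond the scatter), was a different pair of groups on a different core, so the two steps show only that not every aryl swap at this sulfur moves the number beyond the scatter. Nothing available explains the size of either step.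

The compounds shown leave open whether an aryl group on the sulfur carrying an amine or a carboxylic acid, or a saturated chain such as n-butyl in place of the aryl group, would give a step beyond the scatter on the core of compound 1. For the compounds shown here, no pair among them differs only in the double bond, so what that bond contributes on its own remains unread.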